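From Isopropyl to Ethyl: What Compound 4 May Show

The source may report more compounds than this note shows. Statements on the series, on what has been measured and on what is new or still open speak of the compounds shown alone.

In a functional assay on LS174T cells (Homo sapiens) for inhibition, read by MTT assay, with a stated time of 72 h (on this read-out lower numbers stand for stronger inhibition and higher numbers for weaker inhibition), compound 2 `CC(C)c1ccc(C(C)C)c(C(=O)/C=C/C(=O)O)c1` gives 6230 nM, the lowest of the two numbers recorded. Compound 3 `CCc1ccc(C(=O)/C=C/C(=O)O)cc1` gives 21000 nM, a higher number, and the gap between compound 2 and compound 3 lies beyond the usual scatter. Compound 1 `O=C(O)/C=C/C(=O)c1ccc(Cl)cc1Cl` is reported only as a limit of this assay, > 100000 nM; this is the limit of > 100000 nM in this assay, at which 1 of the 3 values shown sits. Compound 4 `CCc1ccc(C(C)C)cc1C(=O)/C=C/C(=O)O` has not yet been measured in this assay; it differs from compound 2 by hydrogen in place of methyl on a saturated chain carbon bound to an aromatic carbon and a saturated chain carbon. No step of this kind has been measured among these compounds, so the direction rests on the change alone. Compound 4 is expected to give a somewhat higher number, with the step of a 1.4-fold higher number from compound 2 to compound 4 (0.16 log units; within the scatter) lying close to the scatter. The estimate for compound 4 is 9000 nM, between 3500 nM and 25000 nM.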

Compound 4, half-maximal inhibitory concentration: 5940 nM
Compound 4: the middle estimate sits 1.5-fold (0.18 log units) above what was measured, and the stated range covers the measured number.
By their numbers in this assay, from the lowest: compounds 4 and 2 (each within the scatter of the next); then compound 3. At a limit, above all of these: compound 1.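

In this assay, the change from isopropyl to ethyl gives a 1.0-fold lower number from compound 2 to compound 4 (0.02 log units; within the scatter) and is the first step of its kind among these compounds. It shows that a methyl on a saturated chain carbon bound to an aromatic carbon and a saturated chain carbon can give way to hydrogen with no difference beyond the scatter, so compound 2 and compound 4 cannot be told apart here. On these data alone, whether a longer chain or an amine at this place would read the same remains open. Nothing shown here gives a cause for this result.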